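Swapping the Chain Amine on a Difluorophenyl Pyridazinone Amide

The source may report more compounds than this note shows. Statements on the series, on what has been measured and on what is new or still open speak of the compounds shown alone.

Of the compounds shown here, two of a shared core have been measured in a functional assay on HT-29 cells (Homo sapiens) for inhibition, read by MTT assay, with a stated time of 72 h; a higher number here means a weaker inhibitor, a lower number a stronger inhibitor. Compound 1 `COc1ccc(-n2nc(C(=O)Nc3ccc(Oc4ccnc5cc(OCCCN6CCN(C)CC6)c(OC)cc45)c(F)c3)c(C)cc2=O)cc1` gives 3520 nM. Compound 2 `COc1cc2c(Oc3ccc(NC(=O)c4nn(-c5ccc(F)c(F)c5)c(=O)cc4C)cc3F)ccnc2cc1OCCCN1CCCC1` gives 150 nM, the lowest of the two numbers, and its distance to compound 1 lies beyond the scatter. Within the data shown here, compound 1 and compound 2 differ in two places at once, and no single step between them is known. Compound 3 `COc1cc2c(Oc3ccc(NC(=O)c4nn(-c5ccc(F)c(F)c5)c(=O)cc4C)cc3F)ccnc2cc1OCCCN1CCN(C)CC1` keeps the difluorophenyl ring of compound 2 and changes only the chain amine: 4-methylpiperazin-1-yl in place of pyrrolidin-1-yl on a saturated chain carbon, three bonds along the chain from an oxygen on an aromatic ring. Compound 1 already carries this 4-methylpiperazin-1-yl group, yet its weaker result cannot be assigned to that group alone. The expected step is therefore small, in no clear direction, a 1.5-fold higher number from compound 2 to compound 3 (0.17 log units; within the scatter), and likely within the scatter. Compound 3 is estimated at 220 nM, with a range from 80 nM to 700 nM.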

Compound 3, half-maximal inhibitory concentration: 170 nM
Compound 3: middle estimate off by 1.3-fold (0.11 log units), on the high side, within the range that was stated.
By their numbers in this assay, from the lowest: compounds 2 and 3 (each within the scatter of the next); then compound 1.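

The change from pyrrolidin-1-yl to 4-methylpiperazin-1-yl on a saturated chain carbon, three bonds along the chain from an oxygen on an aromatic ring, gives a 1.1-fold higher number from compound 2 to compound 3 (0.05 log units; within the scatter) in this assay, so with the difluorophenyl ring in place these two chain amines cannot be told apart. With the chain amine held constant, 3,4-difluorophenyl in place of 4-methoxyphenyl on an aromatic nitrogen gives a 21-fold lower number from compound 1 to compound 3 (1.32 log units; beyond the scatter), which assigns the large gap to that single change, something the two-place pair of compound 1 and compound 2 could not do. Nothing at hand explains either step.

On these data alone, whether a morpholin-4-yl group or a longer chain at this place would also stay within the scatter of compound 2 remains open. So does whether a 4-fluorophenyl group on the aromatic nitrogen would bring a step as large.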